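Swapping the Aryl Group on the Anilino Nitrogen

A few compounds are considered here, and "the series" means these few. Any claim that something is new, unique, unknown or untested is made for them only; others in the source may bear on it.

In an assay on FRT-Jurkat cells for inhibition of nuclear factor NF-kappa-B complex (Homo sapiens), read by flow cytometry, with a stated time of 24 h, tested at 10 uM (on this read-out higher numbers stand for more inhibition at the one concentration tested (going by the name of the read-out) and lower numbers for less inhibition), compound 2 `CC(C)c1ccc(Nc2ccc3c(c2)C(=O)N(C2CCC(=O)NC2=O)C3=O)cc1` gives 11%, while compound 1 `O=C1CCC(N2C(=O)c3ccc(Nc4ccc(O)cc4)cc3C2=O)C(=O)N1` gives 4%, the two numbers sitting within the scatter of each other. Compound 3 `Cc1ccccc1Nc1ccc2c(c1)C(=O)N(C1CCC(=O)NC1=O)C2=O` differs from compound 2 in one place: 2-methylphenyl in place of 4-isopropylphenyl on a nitrogen on an aromatic ring. For the measured compounds named here, the only measured step, a number 7 percentage points higher from compound 1 to compound 2 (within the scatter), concerns a different group and stayed within the scatter, so it offers little guidance for the change at hand. Compound 3 is therefore expected to show no change at the digits printed from compound 2 to compound 3 (within the scatter) in this assay, no step beyond the scatter. The estimate for compound 3 is 11%, ranging from 0% to 25%.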

Compound 3, a percentage reported as inhibition, at one concentration (the size of the read-out at that concentration, not a potency): 2%
Compound 3: middle estimate off by 9 percentage points, on the high side; the measured number falls inside the stated range.
By their numbers in this assay, from the lowest: compounds 3, 1 and 2 (each within the scatter of the next).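

In this assay, 2-methylphenyl on this nitrogen gives a number 9 percentage points lower from compound 2 to compound 3 (within the scatter) when it replaces 4-isopropylphenyl and a number 2 percentage points lower from compound 1 to compound 3 (within the scatter) when it replaces 4-hydroxyphenyl. The three aryl groups on this nitrogen therefore cannot be told apart on this read-out, and a methyl group in the 2-position of the phenyl ring changes the picture no more than the earlier swap did. No evidence at hand bears on this result. Still open, going by these compounds, is whether an amine or a carboxylic acid on this phenyl ring, or an alkyl chain in place of the ring, would move the number beyond the scatter.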